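Reversing the Amide: Compound 1 to Compound 4

This account rests on a few compounds, and the source may have more. Where it says the series, first, only, none or still open, it means among the compounds named here.

Compound 1 `Cc1cc(C(=O)Nc2ccccc2)nn1Cc1cc(Cl)ccc1OCc1ccccc1` carries a phenylcarbamoyl group on its core, and in an in vivo ADME assay on the whole organism for pharmacokinetics, with Rattus norvegicus as the target (on this read-out lower numbers stand for narrower distribution and higher numbers for wider distribution into tissues), compound 1 has no single number, its entry reading "not determined" (no result reported). Two relatives give a footing: in this assay compound 2 `Cc1cc(C(=O)NCc2ccccn2)nn1Cc1cc(Cl)ccc1OCc1ccccc1` gives 3.6 L/kg, and compound 3 `Cc1cc(NC(=O)C2CCOCC2)nn1Cc1cc(Cl)ccc1OCc1ccccc1` gives 3.3 L/kg. The step of a 1.1-fold lower number from compound 2 to compound 3 (0.04 log units; within the scatter) shows that a reversal of the amide, together with the other changes in that pair, left the read-out essentially where it was. Compound 4 `Cc1cc(NC(=O)c2ccccc2)nn1Cc1cc(Cl)ccc1OCc1ccccc1` differs from compound 1 in one place: benzamido in place of phenylcarbamoyl on an aromatic carbon. Among the measured compounds shown here, only that measured step bears on this change, and it lay within the scatter, so no movement beyond the scatter is expected in this assay. The expectation rests on compound 2 at 3.6 L/kg and compound 3 at 3.3 L/kg. Compound 4 is therefore estimated at about 3.4 L/kg, within a range from 1.6 L/kg to 7 L/kg.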

Compound 4, volume of distribution at steady state: 4.1 L/kg
Beside the measured number, compound 4's estimate is 1.2-fold (0.08 log units) below it; low and high end bracket the measured number.
By their numbers in this assay, from the lowest: compounds 3, 2 and 4 (each within the scatter of the next).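

In this assay, phenyl in place of oxan-4-yl on the carbonyl carbon gives a 1.2-fold higher number from compound 3 to compound 4 (0.09 log units; within the scatter), and benzamido in place of ((pyridin-2-yl)methyl)carbamoyl on the aromatic carbon gives a 1.1-fold higher number from compound 2 to compound 4 (0.06 log units; within the scatter). Three different groups at this position thus sit within the scatter of one another, now including one with a phenyl ring on the carbonyl carbon. The step from compound 1 cannot be read, and no supporting data bear on the result. From the compounds shown here alone, whether an amine or a carboxylic acid at this position would shift the read-out remains open.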